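Working notes: one more methoxy on compound 2

This account rests on a few compounds, and the source may have more. Where it says the series, first, only, none or still open, it means among the compounds named here.

In a functional assay on SiHa cells (Homo sapiens) for inhibition, read by sulforhodamine B assay (a higher number here means a weaker inhibitor of growth, a lower number a stronger inhibitor of growth), compound 1 (`COc1cc(-c2ccc(-c3ccc(-c4nc5cc(C)ccc5[nH]4)cc3)cc2)cc(OC)c1OC`) gives 170 nM and compound 2 (`COc1ccc(-c2ccc(-c3ccc(-c4nc5ccccc5[nH]4)cc3)cc2)cc1OC`) gives 6200 nM, the higher of the two numbers and beyond the scatter from compound 1. Compound 3 (`COc1cc(-c2ccc(-c3ccc(-c4nc5ccccc5[nH]4)cc3)cc2)cc(OC)c1OC`) departs from compound 2 by one change, methoxy in place of hydrogen on an aromatic carbon. Among the compounds with values here, no measured pair shows this change alone. Compound 1, at 170 nM, carries the same methoxy pattern as compound 3, though it differs elsewhere. A lower number beyond the scatter is expected, a 16-fold lower number from compound 2 to compound 3 (1.19 log units; beyond the scatter). For compound 3 the estimated value is 400 nM, with an expected range of 120 nM to 1500 nM.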

Compound 3, concentration for 50% growth inhibition: 4980 nM
Compound 3: the middle estimate sits 12-fold (1.10 log units) below what was measured; the measured number lies above the stated range.
By their numbers in this assay, from the lowest: compound 1; then compounds 3 and 2 (each within the scatter of the next).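

In this assay, adding methoxy at this aromatic carbon, ortho to a methoxy group, gives a 1.2-fold lower number from compound 2 to compound 3 (0.10 log units; within the scatter), so this change alone does not separate compound 3 from compound 2. The large step lies instead with the methyl on the core of compound 1: replacing it with hydrogen gives a 29-fold higher number from compound 1 to compound 3 (1.47 log units; beyond the scatter). Nothing available explains either step. As far as these compounds go, whether the methyl matters equally with the methoxy pattern of compound 2 remains open. So does whether an amine or a carboxylic acid in the methyl's place would retain the number of compound 1.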